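This account rests on a few compounds, and the source may have more. Where it says the series, first, only, none or still open, it means among the compounds named here.

Measured so far:

Compound 1 `COc1ccc2[nH]c(=O)c(CN(Cc3ccc(C(C)(C)C)cc3)C(C)c3ccc(OC)c(Cl)c3)cc2c1` — in a toxicity assay on MDCK cells (Canis lupus familiaris) for cytotoxicity, read by crystal violet staining, with a stated time of 48 h (a lower number here means that less compound is tolerated, a higher number that more compound is tolerated), compound 1 gives > 10000 nM, a limit of the assay.
Compound 2 `CN(C)c1ccc(CN(Cc2ccc(C(C)(C)C)cc2)Cc2cc3cc(Br)ccc3[nH]c2=O)cc1` — in this assay compound 2 gives > 10000 nM, again a limit.
Compound 3 `CC(c1ccc(N(C)C)c(Cl)c1)N(Cc1ccc(C(C)(C)C)cc1)Cc1cc2cc(Br)ccc2[nH]c1=O` — in this assay compound 3 gives 6100 nM.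

Among the compounds with values here, compound 3 thus holds the only number in this assay; the other two entries are limits, as summed up by the limit of > 10000 nM in this assay, at which 2 of the 3 values shown sit. Within the data shown here, the one measured step, an at least 1.6-fold lower number from compound 2 to compound 3 (0.21 log units; that floor lies within the scatter), involves 1-(3-chloro-4-(dimethylamino)phenyl)ethyl in place of 4-(dimethylamino)benzyl on the amine nitrogen, and its floor lies within the scatter.

Compound 4 `COc1ccc(C(C)N(Cc2ccc(C(C)(C)C)cc2)Cc2cc3cc(Br)ccc3[nH]c2=O)cc1Cl` is not yet measured. Compared with compound 3 the change is methoxy in place of dimethylamino on an aromatic carbon, ortho to a chloro group and para to a large group, so that 1-(3-chloro-4-(dimethylamino)phenyl)ethyl becomes 1-(3-chloro-4-methoxyphenyl)ethyl. Among the measured compounds shown here, no measured step touches this position; compound 1 carries the same 1-(3-chloro-4-methoxyphenyl)ethyl group and sits at the limit, but differs from compound 4 on the core as well, so no step is drawn between them. The expected step of a 1.5-fold higher number from compound 3 to compound 4 (0.17 log units; within the scatter) is therefore small, within the scatter, leaning toward the limit. Compound 4 is estimated at 9000 nM in this assay, with a range from 4000 nM to 20000 nM.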

Compound 4, half-maximal cytotoxic concentration: > 10000 nM
Compound 4 gave a limit, no number; the forecaster's own chance of this, stated with the estimate: 55%; middle value at least 1.1-fold (0.04 log units) from the limit.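

In this assay, within the data shown here, methoxy in place of dimethylamino on an aromatic carbon, ortho to a chloro group, gives the first measured step at this position: an at least 1.6-fold higher number from compound 3 to compound 4 (0.21 log units; that floor lies within the scatter). Only a floor is known for this step, so the change can be read in direction but not in full size, and the floor itself gives no separation from the scatter. Compound 3 remains the only compound with a number, and the steps from compound 1 and compound 2 to compound 4 cannot be read, leaving this summary for this assay: the limit of > 10000 nM in this assay, at which 3 of the 4 values shown sit.

As far as these compounds go, how far compound 4 lies past its limit stays open, and with it the true size of the change from dimethylamino to methoxy. Also open, from the compounds shown here alone, is whether a hydroxy group, a primary amine or a longer ether such as ethoxy at this position would give a number in this assay, and whether the chloro group matters to the outcome there.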